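Methoxyphenyl for fluorophenyl on the dienone series

A few compounds are considered here, and "the series" means these few. Any claim that something is new, unique, unknown or untested is made for them only; others in the source may bear on it.

Measured so far in a functional assay on LNCaP cells (Homo sapiens) for cytotoxicity, read by MTT assay, with a stated time of 72 h; on this read-out higher numbers stand for weaker inhibition and lower numbers for stronger inhibition:
Compound 1 `CC1=C(/C=C/C(=O)/C=C/c2ccc(F)cc2)C(C)(C)CCC1`: 7300 nM
Compound 2 `CC1=C(/C=C/C(=O)/C=C/c2cccc(F)c2)C(C)(C)CCC1O`: 4400 nM
Compound 3 `CC1=C(/C=C/C(=O)/C=C/c2ccc(F)cc2)C(C)(C)CCC1O`: 3900 nM

Compound 3 sits at the lower end of the three values, but a 1.9-fold lower number from compound 1 to compound 3 (0.27 log units; within the scatter) and a 1.1-fold lower number from compound 2 to compound 3 (0.05 log units; within the scatter) both stay within the scatter, so no separation among the three is established.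

Compound 4 `COc1cccc(/C=C/C(=O)/C=C/C2=C(C)C(O)CCC2(C)C)c1` differs from compound 3 by 3-methoxyphenyl in place of 4-fluorophenyl on a double-bonded chain carbon bound to a double-bonded chain carbon. Only the comparison of compound 2 with compound 3 bears on it, and that step, a move of fluorine between positions on the aromatic ring, was within the scatter. Within the data shown here, no measured pair shows a methoxy group against fluorine, so nothing indicates a shift beyond the scatter in this assay.

Compound 4 is therefore expected near compound 3, with a 1.0-fold higher number from compound 3 to compound 4 (0.01 log units; within the scatter) as the estimated step, giving an estimate of 4000 nM (range 1500 nM to 11000 nM).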

Compound 4, half-maximal inhibitory concentration: 4900 nM
Compound 4: the middle estimate sits 1.2-fold (0.09 log units) below what was measured, and the stated range covers the measured number.
By their numbers in this assay, from the lowest: compounds 3, 2, 4 and 1 (each within the scatter of the next).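

In this assay the step of a 1.1-fold higher number from compound 2 to compound 4 (0.05 log units; within the scatter) is methoxy in place of fluoro on an aromatic carbon, and the step of a 1.3-fold higher number from compound 3 to compound 4 (0.10 log units; within the scatter) is 3-methoxyphenyl in place of 4-fluorophenyl; both stay within the scatter. The earlier compounds shown here showed only fluorine changing place on the aromatic ring, whereas this pair shows that a different group there also leaves the number within the scatter. Nothing available bears on why this is so.

From the compounds shown here alone, whether an amine or a carboxylic acid on the aromatic ring would give a step beyond the scatter remains open.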